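The source may hold more compounds than are shown below. What is called first, only, known or untested is meant among the compounds shown, and "the series" means these compounds.

Compound 1 `c1ccc(-c2cccc3c2CCC3c2ncc[nH]2)nc1` and compound 2 `c1cc(-c2ccn[nH]2)c2c(c1)C(c1ncc[nH]1)CC2` share a core and differ only in the aromatic ring attached to it. In a functional assay on CHO cells for agonist activity at Alpha-1A adrenergic receptor (Homo sapiens), read by FLIPR and calcium flux (a lower number here means a smaller maximal response, a higher number a larger maximal response), compound 1 gives 53%, the lower of the two numbers seen so far, while compound 2 gives 83%. Among the compounds with values here, the one measured step, a number 30 percentage points higher from compound 1 to compound 2 (beyond the scatter), shows that swapping the six-membered ring for a five-membered ring with two hetero atoms can raise the maximal response beyond the scatter. Compound 3 `c1cc(-c2ncco2)c2c(c1)C(c1ncc[nH]1)CC2` makes a related but not identical swap: 1,3-oxazol-2-yl in place of pyridin-2-yl on an aromatic carbon. The oxazole ring, like the pyrazole of compound 2, is five-membered with two hetero atoms, but it carries no hydrogen-bond donor. Within the data shown here, only the step from compound 1 to compound 2 bears on this change, so the expectation for compound 3 is an increase of uncertain size, a number 12 percentage points higher from compound 1 to compound 3 (beyond the scatter), and compound 3 is estimated to give 65%, in a range from 45% to 85%.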

Compound 3, largest response reached (Emax), in percent of the reference or control that the assay uses: 63%
The estimate for compound 3 lay 2 percentage points above the measured number; low and high end bracket the measured number.
By their numbers in this assay, from the lowest: compounds 1 and 3 (each within the scatter of the next); then compound 2.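

At this position, in this assay, having a five-membered aromatic ring with 2 hetero atoms does not by itself set the response apart from that of pyridin-2-yl: 1,3-oxazol-2-yl gives a number 10 percentage points higher from compound 1 to compound 3 (within the scatter). The two five-membered rings also differ from each other, with a number 20 percentage points lower from compound 2 to compound 3 (beyond the scatter), so ring size alone does not decide the number here, and of the three groups only 1H-pyrazol-5-yl stands clear of the other two. Nothing measured here accounts for the gap between the two five-membered rings.

The compounds shown leave open how a thiazole ring, an amine or a carboxylic acid would behave at this position. They also leave open whether the gap between 1H-pyrazol-5-yl and 1,3-oxazol-2-yl would persist on a different core.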